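Replacing a Fluorophenoxy Ether with Phenyl: Stability Outlook

A few compounds are considered here, and "the series" means these few. Any claim that something is new, unique, unknown or untested is made for them only; others in the source may bear on it.

Measured compounds:
compound 1, `CCCCCCCCc1ccc(OCC(=O)Cn2nnnc2C(=O)OCC)cc1`: 33%
compound 2, `CC(Oc1ccc(Oc2ccc(F)cc2)cc1)C(=O)Cn1nnc(-c2ccccc2)n1`: < 5%
compound 3, `CC(Oc1ccc(Oc2ccc(F)cc2)cc1)C(=O)Cn1nnc(-c2ccc(Cl)cc2)n1`: < 5%

In an ADME assay on S9 fraction from liver (Rattus norvegicus) for metabolic stability, read by LC-MS, using NADPH, with a stated time of 30 min (on this read-out higher numbers stand for a more stable compound and lower numbers for a less stable compound), compound 1 gives 33%. Compound 2 reaches only < 5%, which is a limit of this assay and not a number. Compound 3 likewise sits at < 5%, again a limit. The step that the two limits leave unreadable from compound 2 to compound 3 is therefore unreadable, because the limit of < 5% in this assay, at which 2 of the 3 values shown sit, hides both ends. Compound 4, `CC(Oc1ccc(-c2ccccc2)cc1)C(=O)Cn1nnc(-c2ccc(Cl)cc2)n1`, differs from compound 3 by phenyl in place of 4-fluorophenoxy on an aromatic carbon. Within the data shown here, no measured step covers this change, so the expectation rests on where compound 3 stands. Compound 4 is expected to remain weakly stable, estimated at 8% (0% to 30%). The expected step of a number at least 3 percentage points higher from compound 3 to compound 4 (that floor lies within the scatter) is small and may again end at the limit.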

Compound 4, percent of the compound remaining: 18%
Beside the measured number, compound 4's estimate is 10 percentage points below it; the measured number falls inside the stated range.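

Putting phenyl in place of 4-fluorophenoxy, on the aromatic carbon para to a large group, gives the first readable step among these close analogues: in this assay it is a number at least 13 percentage points higher from compound 3 to compound 4 (beyond the scatter). So this position can shift the read-out, something the earlier chloro change could not show, as that step cannot be read. The full size of the new step stays unknown because compound 3 rests on a limit: the limit of < 5% in this assay, at which 2 of the 4 values shown sit.

The compounds shown do not separate the loss of the ether oxygen from the loss of the fluorine. As far as these compounds go, how a plain phenoxy group or an amine would behave at this position also remains open.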